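Chloro in place of ethoxy on the shared core

The source may report more compounds than this note shows. Statements on the series, on what has been measured and on what is new or still open speak of the compounds shown alone.

Measured in a functional assay on MOLT-4 cells (Homo sapiens); a higher number here means a weaker inhibitor, a lower number a stronger inhibitor
compound 1 `Nc1ncnc2c1ncn2C[C@@H]1C[C@H](CO)c2ccccc21` gives 24 ug/mL
compound 2 `Cc1ccc(-c2ncnc3c2ncn3C[C@@H]2C[C@H](CO)c3ccccc32)cc1` gives 1.4 ug/mL
compound 3 `CCOc1ncnc2c1ncn2C[C@@H]1C[C@H](CO)c2ccccc21` gives 24 ug/mL

Level with compound 1, compound 3 reads 24 ug/mL as the joint highest number of the three. The next compound, compound 4 `OC[C@H]1C[C@@H](Cn2cnc3c(Cl)ncnc32)c2ccccc21`, has chloro in place of ethoxy on an aromatic carbon and is still to be measured in this assay on the same cells.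

All three measured steps fall at this same carbon. Exchanging amino for ethoxy gave no change at the digits printed from compound 1 to compound 3 (within the scatter) and stayed within the scatter. Only 4-methylphenyl moved the number, with a 17-fold lower number from compound 1 to compound 2 (1.23 log units; beyond the scatter) as a large step and a 17-fold higher number from compound 2 to compound 3 (1.23 log units; beyond the scatter) as its large reverse. Chloro brings no ring, so the closer precedent is expected to be compound 1 with its no change at the digits printed from compound 1 to compound 3 (within the scatter) rather than compound 2. For the measured compounds named here, no measured compound carries chloro, so the range is kept wide and leans slightly toward lower numbers.

The expected change is a 1.6-fold lower number from compound 3 to compound 4 (0.20 log units; within the scatter) and is not expected to go beyond the scatter. For compound 4 the estimated value is 15 ug/mL with an expected range from 4 ug/mL to 50 ug/mL in this read-out.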

Compound 4, half-maximal inhibitory concentration: 24 ug/mL
Compound 4: the middle estimate sits 1.6-fold (0.20 log units) below what was measured; low and high end bracket the measured number.
By their numbers in this assay, from the lowest: compound 2; then compounds 1, 3 and 4 (each within the scatter of the next).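

In this assay, chloro now stands with amino and ethoxy on this aromatic carbon, with no change at the digits printed from compound 3 to compound 4 (within the scatter) and no change at the digits printed from compound 1 to compound 4 (within the scatter), so the three groups without a ring cannot be told apart here. Against chloro as well, the 4-methylphenyl of compound 2 stands apart, with a 17-fold higher number from compound 2 to compound 4 (1.23 log units; beyond the scatter), which makes compound 2 the strongest inhibitor of the four and the only one in the set that departs from the common reading. The large step therefore goes with this one group rather than with every replacement of amino at this position, although nothing available explains why the three groups read alike or why 4-methylphenyl differs.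

Still open, going by these compounds, is whether the step needs the aromatic ring alone or also its methyl, which plain phenyl, 4-methoxyphenyl or a pyridine ring on the same carbon would help to separate. Also open, on these data alone, is how a longer chain such as butoxy or a benzylamine at this carbon would read, and whether a carboxylic acid in place of the hydroxymethyl would change the picture.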